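The compounds below may be only part of what the source reports. "The series", "measured", "known", "first", "only" and "open" are said of these compounds alone.

In a functional assay on HepG2 cells (Homo sapiens) for inhibition, read by MTT assay, with a stated time of 48 h (on this read-out lower numbers stand for stronger inhibition and higher numbers for weaker inhibition), compound 1 `COc1ccc(-n2c(S)nnc2-c2cc(OC)c(OC)c(OC)c2)cc1` gives 57500 nM. Compound 2 `COc1ccc(-n2c(SC)nnc2-c2cc(OC)c(OC)c(OC)c2)cc1` reaches only a limit of the assay, > 60000 nM. Compound 3 `COc1ccc(-n2c(SCC(=O)c3ccc(OC)c(O)c3)nnc2-c2cc(OC)c(OC)c(OC)c2)cc1` also has no number, only a limit, > 60000 nM. Compound 4 `COc1ccc(NC(=O)CSc2nnc(-c3cc(OC)c(OC)c(OC)c3)n2-c2ccc(OC)cc2)cc1` carries (4-methoxyphenyl)amino in place of 3-hydroxy-4-methoxyphenyl on a carbonyl carbon. The measured steps that bear on this are an at least 1.0-fold higher number from compound 1 to compound 2 (0.01 log units; that floor lies within the scatter) and an at least 1.0-fold higher number from compound 1 to compound 3 (0.01 log units; that floor lies within the scatter), while a step that the two limits leave unreadable from compound 2 to compound 3 cannot be sized. None of them shows a readable change beyond the scatter, so no step beyond the scatter is expected, and the estimated step is an at least 1.0-fold lower number from compound 3 to compound 4 (0.03 log units; that floor lies within the scatter). Compound 4 is expected at 55000 nM, with an estimated range of 15000 nM to 120000 nM.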

Compound 4, half-maximal inhibitory concentration: > 60000 nM
Compound 4 gave a limit, no number; the forecaster's own chance of this, stated with the estimate: 65%; middle value at least 1.0-fold (0.03 log units) from the limit.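

In this assay, compound 4 gives only a limit, not a number, so (4-methoxyphenyl)amino on the carbonyl carbon yields no more of a reading than 3-hydroxy-4-methoxyphenyl does there. For the compounds shown here, the steps among compound 2, compound 3 and compound 4 cannot be read, and the one readable step is an at least 1.0-fold higher number from compound 1 to compound 4 (0.01 log units; that floor lies within the scatter). The comparison stops at one limit: the limit of > 60000 nM in this assay, at which 3 of the 4 values shown sit.

On these data alone, whether an amine or a carboxylic acid in place of (4-methoxyphenyl)amino on the carbonyl carbon would give a number inside that limit stays open.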